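Phenoxy to Pyridyloxy on an Aryl Ether Series

This account rests on a few compounds, and the source may have more. Where it says the series, first, only, none or still open, it means among the compounds named here.

Among the measured compounds shown here, compound 2 `CC(C)CCn1ccc(-c2ccc(Oc3ccccc3)cc2)c(C#N)c1=O` is one of two compounds measured in a functional assay on CHO cells for positive allosteric modulation of metabotropic glutamate receptor 2 (Homo sapiens), read by scintillation counting and GTPgammaS binding, with a stated time of 30 min; on this read-out higher numbers stand for larger maximal responses and lower numbers for smaller maximal responses. In this assay compound 2 gives 188%, the higher of the two numbers. For the measured compounds named here, compound 1 `COc1ccc(-c2ccn(CCC(C)C)c(=O)c2C#N)cc1F` is the only other compound with a measurement; in this assay compound 1 gives 160%, a gap beyond the usual scatter that places compound 2 at the top of the two. Going by the values given here, no pair of measured compounds differs in a single place, so no measured step is available to guide a prediction. Compound 3 `Cc1cc(Oc2ccc(-c3ccn(CCC(C)C)c(=O)c3C#N)cc2)ccn1` has not yet been measured. It differs from compound 2 by 2-methylpyridin-4-yl in place of phenyl on an oxygen on an aromatic ring. Among the compounds with values here, with no comparable step measured, compound 3 is expected to fall near compound 2, and the step of a number 13 percentage points lower from compound 2 to compound 3 (beyond the scatter) is estimated to be small and within the scatter in either direction. Compound 3 is therefore expected to give about 175% in this assay, within a range from 125% to 225%.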

Compound 3, largest response reached (Emax), in percent of the reference or control that the assay uses: 266%
Compound 3: the middle estimate sits 91 percentage points below what was measured; the measured number lies above the stated range.
By their numbers in this assay, from the lowest: compound 1; then compound 2; then compound 3.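

In this assay, among the compounds shown here, putting 2-methylpyridin-4-yl in place of phenyl on this oxygen gives a number 78 percentage points higher from compound 2 to compound 3 (beyond the scatter), the first measured step. It shows that the maximal response depends strongly on the group held on this oxygen, and that a six-membered aromatic ring with one hetero atom and a methyl group is tolerated here with a large gain rather than a loss. For the compounds shown here, nothing measured so far accounts for the size of this step.

The ring nitrogen and the methyl group enter together, so the compounds shown do not tell how much of the step belongs to each. Going by these compounds, whether pyridin-4-yl without the methyl group, or 3-methylphenyl, on the same oxygen would keep this gain remains open, as does whether the gain would carry over to other groups on the shared core.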